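Stereocentre inversion in salicylamide series: cytotoxicity working notes

The compounds below may be only part of what the source reports. "The series", "measured", "known", "first", "only" and "open" are said of these compounds alone.

Compound 1 `Cc1ccc(O)c(C(=O)NCCCN(C(C)C)C(C)C)c1`: in a functional assay on MDBK cells (Bos taurus) for cytotoxicity (a lower number here means that less compound is tolerated, a higher number that more compound is tolerated), compound 1 gives > 100 ug/mL, which is a limit of the assay.
Compound 2 `O=C(NCCCN1CCC[C@@H]2CCCC[C@@H]21)c1cc(Cl)ccc1O`: in this assay compound 2 gives 43 ug/mL.
Compound 3 `CC1CC[C@@H]2CCCC[C@@H]2N1CCCNC(=O)c1cc(Cl)ccc1O`: in this assay compound 3 gives 40 ug/mL.

Compound 2 stands alongside compound 3, the two numbers lying within the scatter of each other. Compound 1 sits at a limit (the limit of > 100 ug/mL in this assay, at which 1 of the 3 values shown sits). For the measured compounds named here, the single measured step that changes one feature, a 1.1-fold lower number from compound 2 to compound 3 (0.03 log units; within the scatter), is within the scatter.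

Compound 4 `O=C(NCCCN1CCC[C@@H]2CCCC[C@H]21)c1cc(Cl)ccc1O` differs from compound 2 only in configuration: the two compounds have the same atoms and bonds and differ only in configuration as drawn: 1 of 2 stereo elements differ; a stereocentre at a saturated ring carbon is drawn S in compound 2 and R in compound 4. No measured step involves a change of configuration, so nothing shown bears directly on this change, and the one measured step was within the scatter. The expected step from compound 2 to compound 4 is therefore none beyond the scatter, no change at the digits printed from compound 2 to compound 4 (within the scatter). Compound 4 is expected to give about 43 ug/mL in this assay, within 20 ug/mL to 90 ug/mL.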

Compound 4, half-maximal cytotoxic concentration: 45 ug/mL
Compound 4: middle estimate off by 1.0-fold (0.02 log units), on the low side, within the range that was stated.
By their numbers in this assay, from the lowest: compounds 3, 2 and 4 (each within the scatter of the next). At a limit, above all of these: compound 1.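

In this assay, inverting the stereocentre at the saturated ring carbon gives a 1.0-fold higher number from compound 2 to compound 4 (0.02 log units; within the scatter), so S and R at this position cannot be told apart by this read-out. For the compounds shown here, until now the only measured step was a methyl in place of hydrogen; this step tests configuration alone, and the comparison is clean for one reason: the fact that compounds 2 and 4 differ only in the configuration as drawn.

On these data alone, whether inverting the other stereocentre, or both together, behaves the same way remains open. So does the effect of a longer chain in place of the present one, or of fluorine in place of chlorine.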